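Trading a Cyclopentenyl Acid for a Small Cyclopropyl Ring

The compounds below may be only part of what the source reports. "The series", "measured", "known", "first", "only" and "open" are said of these compounds alone.

Of the compounds shown here, three sharing one core have been measured in a functional assay for antagonist activity at adenosine receptor A1 (Homo sapiens); a higher number here means a weaker inhibitor, a lower number a stronger inhibitor. Compound 1 `CCCn1c(=O)c2nc(C3CCC(C(=O)OC)CC3)[nH]c2n(CCC)c1=O` gives 130 nM, and compound 2 `CCCn1c(=O)c2nc(C3CCC(NC(C)=O)CC3)[nH]c2n(CCC)c1=O` gives 70 nM; 12 nM (2 entries); the spread for compound 2 comes from the several entries of compound 2 in this assay, 70 nM; 12 nM (2 entries). Compound 3 `CCCn1c(=O)c2nc(C3=C(C(=O)O)CCC3)[nH]c2n(CCC)c1=O` stands apart: in this assay compound 3 reaches only a limit, > 10000 nM, which marks the edge of what the assay can report rather than a number. Compound 4 `CCCn1c(=O)c2nc(C3CC3C)[nH]c2n(CCC)c1=O` has not yet been measured. It differs from compound 3 in one place: 2-methylcyclopropyl in place of 2-carboxycyclopent-1-en-1-yl on an aromatic carbon. The change removes both the carboxylic acid and the five-membered ring and puts a small three-membered carbon ring in their place. Since compound 3 gives only a limit, the size of this step cannot be read from any measured pair. Compound 4 is expected to be a clearly stronger inhibitor, with the step of an at least 200-fold lower number from compound 3 to compound 4 (2.30 log units; beyond the scatter) well beyond the scatter. In this assay compound 4 is estimated at 50 nM, within a range from 10 nM to 300 nM.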

Compound 4, inhibition constant: 11 nM
For compound 4 the middle estimate is 4.5-fold (0.66 log units) above the measured one; the measured number falls inside the stated range.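

In this assay the swap of 2-carboxycyclopent-1-en-1-yl for 2-methylcyclopropyl, on the aromatic carbon between two ring nitrogen atoms, gives an at least 900-fold lower number from compound 3 to compound 4 (2.95 log units; beyond the scatter). Within the data shown here, this is the first measured step at this position, and it shows that the position can hold a group of only 4 carbon atoms, with no carboxylic acid and no hydrogen-bond donors or acceptors, and still give a low number. As far as these compounds go, the true size of the step stays unknown because compound 3 is held at a limit rather than a number: the limit of > 10000 nM in this assay, at which 1 of the 4 values shown sits.

The change removes the carboxylic acid and the five-membered ring at once, so this one pair cannot tell which of the two carries the step. A cyclopentenyl ring without the acid, or a cyclopropyl ring carrying a carboxylic acid, would separate the two.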